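Shortening the ether side chain on a stable trioxolane series

The compounds below may be only part of what the source reports. "The series", "measured", "known", "first", "only" and "open" are said of these compounds alone.

Measured compounds:
compound 1 `c1cc([C@H]2CC[C@]3(CC2)OOC2(O3)C3CC4CC(C3)CC2C4)ccc1OCCC1CCNCC1` — < 7 mL.min-1.g-1
compound 2 `O[C@H]1CC[C@H](NCCCOc2ccc([C@H]3CC[C@]4(CC3)OOC3(O4)C4CC5CC(C4)CC3C5)cc2)CC1` — < 7 mL.min-1.g-1

The series shares the core shown in compound 1, with variation only in the chain that leaves the oxygen on the aromatic ring. In an ADME assay on microsomes from liver (Homo sapiens) for metabolic stability, read by LC-MS, tested at 1 uM (a lower number here means slower removal, a higher number faster removal of the compound), compound 1 gives < 7 mL.min-1.g-1, a limit of the assay rather than a number. In this assay compound 2 likewise gives < 7 mL.min-1.g-1, again a limit. Within the data shown here, the one measured step, a step that the two limits leave unreadable from compound 1 to compound 2, therefore cannot be read, as both ends rest on a limit; what is known is the limit of < 7 mL.min-1.g-1 in this assay, at which 2 of the 2 values shown sit.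

Compound 3 `N[C@H]1CC[C@H](Oc2ccc([C@H]3CC[C@]4(CC3)OOC3(O4)C4CC5CC(C4)CC3C5)cc2)CC1` is not yet measured. Against compound 2 the change is 4-aminocyclohexyl in place of 3-((4-hydroxycyclohexyl)amino)propyl on an oxygen on an aromatic ring. Among the measured compounds shown here, no measured step bears directly on this change, and the only step available was unreadable. Both measured compounds sit at the limit, so compound 3 is expected to stay near it too, with the estimated step that the limit leaves unreadable from compound 2 to compound 3. In this assay compound 3 is estimated at 5 mL.min-1.g-1, expected between 2 mL.min-1.g-1 and 14 mL.min-1.g-1, with a fair chance that only a limit is reported.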

Compound 3, intrinsic clearance in microsomes: < 7 mL.min-1.g-1
Compound 3 was reported as a limit; the forecaster's own chance of this, stated with the estimate: 65%; the middle value is on the limit's open side.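

In this assay compound 3 gives < 7 mL.min-1.g-1, again a limit of the assay. The steps from compound 1 and compound 2 to compound 3 therefore cannot be read, and the three compounds share one result: the limit of < 7 mL.min-1.g-1 in this assay, at which 3 of the 3 values shown sit. The compounds shown leave open how their true clearances compare, and whether any change to the chain on the oxygen would produce a readable value.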